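Fluoromethyl to difluoromethyl in the HL-60 series

A few compounds are considered here, and "the series" means these few. Any claim that something is new, unique, unknown or untested is made for them only; others in the source may bear on it.

Compound 1 `O=c1[nH]c(=O)n([C@H]2C[C@H](O)[C@@H](CO)O2)cc1CF`: > 1000 uM (a limit)
Compound 2 `CC(=O)OC[C@H]1O[C@@H](n2cc(C(F)F)c(=O)[nH]c2=O)C[C@@H]1OC(C)=O`: 14 uM

In a functional assay on HL-60 cells (Homo sapiens) for inhibition, with a stated time of 72 h (on this read-out lower numbers stand for stronger inhibition and higher numbers for weaker inhibition), compound 1 stands only at a limit, > 1000 uM, and has no number of its own. Compound 3 `O=c1[nH]c(=O)n([C@H]2C[C@H](O)[C@@H](CO)O2)cc1C(F)F` differs from it by fluoro in place of hydrogen on a saturated chain carbon bound to an aromatic carbon and a fluorine atom. Within the data shown here, no measured step covers this change in this assay. A large gain in inhibition, beyond the scatter, is still expected, guided by compound 2 at 14 uM. The expected change is an at least 25-fold lower number from compound 1 to compound 3 (1.39 log units; beyond the scatter). The estimate for compound 3 is 40 uM, with an expected range of 6 uM to 400 uM.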

Compound 3, concentration for 50% inhibition: 0.12 uM
The estimate for compound 3 lay 330-fold (2.52 log units) above the measured number; measured number below the stated range.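

In this assay the change from fluoromethyl to difluoromethyl on the shared core gives an at least 8300-fold lower number from compound 1 to compound 3 (3.92 log units; beyond the scatter) and shows that this one position responds strongly to a single added fluoro. Compound 1 has only a limit, > 1000 uM and no number of its own. The full size of the step therefore cannot be read, only its lower bound: the limit of > 1000 uM in this assay, at which 1 of the 3 values shown sits.

Open, on these data alone, is whether trifluoromethyl at this place carries the gain further or loses it. Also open, as far as these compounds go, is how a plain methyl or a longer chain, such as ethyl, would fare there.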